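This account rests on a few compounds, and the source may have more. Where it says the series, first, only, none or still open, it means among the compounds named here.

Compound 1 `COc1cc(/C=C/C(=O)c2cccc(NC(=O)c3cccs3)c2)ccc1O` gives 71% in a functional assay on HUVEC cells (Homo sapiens) for inhibition, tested at 2.5 ug/mL; a higher number here means a stronger effect of the compound at the concentration tested, a lower number a weaker effect. Compound 2 `COc1cc(/C=C/C(=O)c2cccc(N)c2)ccc1O` gives 20%. Compound 3 `COc1cc(/C=C/C(=O)c2cccc(NC(=O)C(C)C)c2)ccc1O` gives 11%.

Compound 3 stands lowest of the three numbers. Its nearest neighbour is compound 2, and that step, a number 9 percentage points lower from compound 2 to compound 3 (within the scatter), lies within the scatter. The furthest is compound 1: a number 60 percentage points lower from compound 1 to compound 3 (beyond the scatter), a large drop that accompanies isopropyl in place of thiophen-2-yl on the carbonyl carbon. The same pattern appears in a number 51 percentage points lower from compound 1 to compound 2 (beyond the scatter).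

Compound 4 `CCCC(=O)Nc1cccc(C(=O)/C=C/c2ccc(O)c(OC)c2)c1` is the next compound to be examined. It differs from compound 3 as follows: propyl in place of isopropyl on a carbonyl carbon. Of the measured steps, only the two that touch the group on the carbonyl carbon bear on this, and both say the same thing: a ring in that position goes with a high reading, while hydrogen or isopropylcarbonyl give low readings that do not differ from each other beyond the scatter. Going from isopropylcarbonyl to propylcarbonyl is a smaller change than either of those, so compound 4 is expected to show a number 3 percentage points higher from compound 3 to compound 4 (within the scatter), a step not beyond the scatter. The estimate for compound 4 is therefore 14%, in the range 3% to 30%.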

Compound 4, a percentage reported as inhibition, at one concentration (the size of the read-out at that concentration, not a potency): 40%
Compound 4: the middle estimate sits 26 percentage points below what was measured; measured number outside the range, above it.
By their numbers in this assay, from the lowest: compounds 3 and 2 (each within the scatter of the next); then compound 4; then compound 1.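

In this assay, the arrangement of the chain on the carbonyl carbon matters and not only its size: isopropyl and propyl both have 3 carbons and no ring, yet the swap gives a number 29 percentage points higher from compound 3 to compound 4 (beyond the scatter) and the propyl amide separates from the free amine, with a number 20 percentage points higher from compound 2 to compound 4 (beyond the scatter) in place of the within-scatter step seen for isopropylcarbonyl. A ring at this position is therefore not needed to lift the reading above the low pair, although thiophen-2-yl keeps a clear lead, with a number 31 percentage points lower from compound 1 to compound 4 (beyond the scatter) still to make up. Nothing among the available data explains why the two chains differ.

Still open, as far as these compounds go, is whether a longer chain such as butyl or pentyl would raise the reading further toward that of compound 1. From the compounds shown here alone, it is equally open whether the high reading belongs to thiophen-2-yl specifically or would also appear with phenyl or furan-2-yl on the carbonyl carbon.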